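This account rests on a few compounds, and the source may have more. Where it says the series, first, only, none or still open, it means among the compounds named here.

Compound 1 `Cc1nnsc1CO/N=C/c1c(C)nn(C)c1Oc1ccc(F)cc1` gives > 50000 nM (a limit)
Compound 2 `Cc1nnsc1CO/N=C/c1c(C)nn(C)c1Oc1ccccc1OC(F)(F)F` gives > 50000 nM (a limit)
Compound 3 `Cc1nnsc1CO/N=C/c1c(C)nn(C)c1Oc1cccc(F)c1F` gives 10200 nM (a number)

In a functional assay on Huh-7 cells (Homo sapiens) for inhibition, read by MTT assay, with a stated time of 48 h (a lower number here means a stronger inhibitor, a higher number a weaker inhibitor), compound 1 gives > 50000 nM as a limit and not a number. Compound 1 sits on the limit of > 50000 nM in this assay, at which 2 of the 3 values shown sit, and so has no exact place on the scale.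

Compound 4 `Cc1nnsc1CO/N=C/c1c(C)nn(C)c1Oc1cc(F)cc(F)c1` differs from it by 3,5-difluorophenyl in place of 4-fluorophenyl on an oxygen on an aromatic ring in the same place. Among the compounds with values here, the one measured step that bears on this change is an at least 4.9-fold lower number from compound 1 to compound 3 (0.69 log units; beyond the scatter) and also replaces 4-fluorophenyl with a difluorophenyl group. On that step alone, a change towards a lower number is expected, of similar or smaller size, and a second limit reading remains possible. The expected step is an at least 2.5-fold lower number from compound 1 to compound 4 (0.39 log units; beyond the scatter) for this change. Compound 4 is estimated at 20000 nM with an expected range from 8000 nM to 50000 nM in this measurement.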

Compound 4, half-maximal inhibitory concentration: > 50000 nM
Compound 4 gave a limit, no number; the forecaster's own chance of this, stated with the estimate: 40%; at least 2.5-fold (0.39 log units) between middle value and limit.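

In this assay, the difluorophenyl groups on this oxygen are not interchangeable: 3,5-difluorophenyl in place of 2,3-difluorophenyl gives an at least 4.9-fold higher number from compound 3 to compound 4 (0.69 log units; beyond the scatter). Within the data shown here, a second fluorine is therefore not enough on its own to give a measurable number, and compound 3 remains the only compound with one. The step from compound 1 to compound 4 cannot be read, since both values are limits, as most values here are: the limit of > 50000 nM in this assay, at which 3 of the 4 values shown sit.

Going by these compounds, it remains open whether a methoxy group or an amine on this phenyl ring, in place of fluorine, would give a number in this assay. On these data alone, it is also open whether a 2,3-dichlorophenyl group would match compound 3.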